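Fluoro substitution on the aryl urea of compound 1

The source may report more compounds than this note shows. Statements on the series, on what has been measured and on what is new or still open speak of the compounds shown alone.

Working notes on a small set of aryl ureas built on one shared core. Compound 1 `C[C@@H](NC(=O)Nc1cccc(F)c1)c1ccccc1` and compound 2 `C[C@H](NC(=O)Nc1ccc(F)cc1)c1ccccc1` are made of the same atoms joined differently; the difference between the two cores is not broken down here. Compound 3 `C[C@H](NC(=O)Nc1ccc(F)cc1F)c1ccccc1` carries one more fluoro group than compound 2, the change being (fluoro in place of hydrogen on an aromatic carbon). Compound 4 `C[C@@H](NC(=O)Nc1cc(F)ccc1F)c1ccccc1`, not yet measured, stands in the corresponding relation to compound 1, the change being (fluoro in place of hydrogen on an aromatic carbon).

In an ADME assay on the whole organism with Oryza sativa as the target, tested at 10 uM (on this read-out higher numbers stand for a weaker effect at the one concentration tested and lower numbers for a stronger effect), compound 1 gives 84%, compound 2 gives 85% and compound 3 gives 99%. The values of compound 1 and compound 2 lie within the scatter of each other, so nothing is read into their order. Among the measured compounds shown here, the single measured change of this type is a number 14 percentage points higher from compound 2 to compound 3 (beyond the scatter), and it is the only guide available for compound 4. The surroundings of the entering fluoro group are not identical, however: in compound 3 it sits meta to a fluoro group, in compound 4 para to a fluoro group, so the two changes are of the same kind rather than the same. For the measured compounds named here, with only one measured example, no pattern beyond these compounds is claimed.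

For compound 4 a step of a number 11 percentage points higher from compound 1 to compound 4 (beyond the scatter) is expected in this assay, resting on the measured a number 14 percentage points higher from compound 2 to compound 3 (beyond the scatter) applied to the starting point of compound 1 at 84%, with the read-out unable to rise far beyond where compound 3 already stands. Compound 4 is therefore estimated at 95%, with the likely range running from 86% to 100%.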

Compound 4, a percentage reported as activity, at one concentration (the size of the read-out at that concentration, not a potency): 92%
Estimate against measurement, compound 4: 3 percentage points above, and the stated range covers the measured number.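

On the core of compound 1, fluoro in place of hydrogen on an aromatic carbon gives, in this assay, a number 8 percentage points higher from compound 1 to compound 4 (within the scatter), so this step alone cannot be told apart from no change. Set beside the earlier step, it gives no sign that the change behaves differently on the two cores: the same change on two cores in this assay, a number 14 percentage points higher (beyond the scatter) from compound 2 to compound 3 and a number 8 percentage points higher (within the scatter) from compound 1 to compound 4, 6 percentage points apart, within the scatter of two such steps

Among the compounds shown here, this does not establish that the step has a fixed size, as only two pairs are available, only one of the two steps lies beyond the scatter, and the entering fluoro group has different surroundings in each pair, being para to a fluoro group in compound 4.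

The compounds shown leave open whether a group other than fluoro at this place on the aromatic ring, such as chloro, methoxy or a nitrile, would shift the read-out in the same direction. Also open, going by these compounds, is how the read-out responds to changes elsewhere on the shared core, for example an amine or a carboxylic acid on the unsubstituted aromatic ring, or a longer chain in place of the methyl group.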